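A few compounds are considered here, and "the series" means these few. Any claim that something is new, unique, unknown or untested is made for them only; others in the source may bear on it.

Measured compounds:
Compound 1 `COc1cc2cc(C(=O)NCc3ccc(F)cc3)c(=O)oc2cc1OCCCOc1no[n+]([O-])c1S(=O)(=O)c1ccccc1`, in a functional assay on MCF7 cells (Homo sapiens) for inhibition, read by MTT assay, with a stated time of 48 h (on this read-out higher numbers stand for weaker inhibition and lower numbers for stronger inhibition), compound 1 gives 370 nM.
Compound 2 `COc1ccc(CNC(=O)c2cc3cc(OC)c(OCCCOc4no[n+]([O-])c4S(=O)(=O)c4ccccc4)cc3oc2=O)cc1`, compound 2 gives 560 nM.
Compound 3 `COc1ccc(NC(=O)c2cc3cc(OC)c(OCCCOc4no[n+]([O-])c4S(=O)(=O)c4ccccc4)cc3oc2=O)cc1`, compound 3 gives 410 nM.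

All three share one core and differ only in the group carried on the amide-type nitrogen. Compound 3 sits second highest of the three numbers, yet its nearest neighbour compound 1 and its furthest neighbour compound 2 both lie within the scatter of it, so no order among the three can be claimed. The steps swapping the group on that nitrogen were small: a 1.1-fold higher number from compound 1 to compound 3 (0.04 log units; within the scatter) and a 1.4-fold lower number from compound 2 to compound 3 (0.14 log units; within the scatter), as was a 1.5-fold higher number from compound 1 to compound 2 (0.18 log units; within the scatter).

Compound 4 `COc1cc2cc(N)c(=O)oc2cc1OCCCOc1no[n+]([O-])c1S(=O)(=O)c1ccccc1` goes further: amino in place of (4-methoxyphenyl)carbamoyl on an aromatic carbon. Within the data shown here, this removes the whole carbamoyl arm rather than varying its end, so none of the measured steps bears on it directly; they only show that changes at the end of the arm left the number nearly unchanged. With such a large truncation the outcome is uncertain, and an expectation is set by the shared core and a wide range. Compound 4 is expected to give 1200 nM, between 350 nM and 5000 nM. The expected step is a 2.9-fold higher number from compound 3 to compound 4 (0.47 log units; beyond the scatter).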

Compound 4, half-maximal inhibitory concentration: 2020 nM
Estimate against measurement, compound 4: 1.7-fold (0.23 log units) below, and the stated range covers the measured number.
By their numbers in this assay, from the lowest: compounds 1, 3 and 2 (each within the scatter of the next); then compound 4.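

The earlier compounds shown here varied only the far end of the arm on this aromatic carbon, and those swaps stayed within the scatter in this assay. Among these compounds, removing the whole arm and leaving amino is the first change at this position that goes beyond the scatter, with a 4.9-fold higher number from compound 3 to compound 4 (0.69 log units; beyond the scatter), a 3.6-fold higher number from compound 2 to compound 4 (0.56 log units; beyond the scatter) and a 5.5-fold higher number from compound 1 to compound 4 (0.74 log units; beyond the scatter). All three arms, whichever end they carry, therefore go with stronger inhibition than amino does here, and no accompanying measurement bears on why the number rises when the arm is lost.

The step to amino removes the carbonyl, the amide nitrogen's substituent and the aromatic ring together, so the compounds shown cannot say which of these parts matters, and a short methylcarbamoyl group at the same carbon would keep the carbonyl while dropping the ring. A carboxylic acid at this carbon, or plain hydrogen in place of amino, would likewise show whether the amino group itself has any bearing on the number.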